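Fluoro for hydrogen on an isopropyl group across the series

The compounds below may be only part of what the source reports. "The series", "measured", "known", "first", "only" and "open" are said of these compounds alone.

Compound 1 `Cc1nc(S(C)(=O)=O)ccc1Oc1ncnc(OC2CCN(C(=O)OC(C)C)CC2)c1F` gives 77% in a functional assay on isolated protein for inhibition of Glucose-dependent insulinotropic receptor (Rattus norvegicus), read by HTRF and cAMP accumulation; on this read-out lower numbers stand for smaller maximal responses and higher numbers for larger maximal responses. Compound 2 `Cc1nc(S(C)(=O)=O)ccc1Oc1ncnc(OC2CCN(C(=O)O[C@@H](C)CF)CC2)c1F` carries fluoro in place of hydrogen on a saturated chain carbon, two bonds along the chain from an oxygen next to a carbonyl group and in this assay compound 2 gives 84%; the step is a number 7 percentage points higher from compound 1 to compound 2 (within the scatter). Compound 3 `Cc1nc(S(C)(=O)=O)ccc1Oc1ncnc(OC2CCN(C(=O)c3noc(C(C)C)n3)CC2)c1F` differs from compound 1 by 5-isopropyl-1,2,4-oxadiazol-3-yl in place of isopropoxy on a carbonyl carbon; in this assay compound 3 gives 81%, a step of a number 4 percentage points higher from compound 1 to compound 3 (within the scatter), while against compound 2 it reads a number 3 percentage points lower from compound 2 to compound 3 (within the scatter). Compound 4 `Cc1nc(S(C)(=O)=O)ccc1Oc1ncnc(OC2CCN(C(=O)c3noc(C(C)(C)F)n3)CC2)c1F` is not yet measured and carries fluoro in place of hydrogen on a saturated chain carbon bound to an aromatic carbon and two saturated chain carbons. Among the measured compounds shown here, this is the same kind of change as the one seen in compound 2, but the place differs: there the saturated chain carbon is two bonds along the chain from an oxygen next to a carbonyl group, here it is bound to an aromatic carbon and two saturated chain carbons. The expected step of a number 3 percentage points higher from compound 3 to compound 4 (within the scatter) rests on the measured step of a number 7 percentage points higher from compound 1 to compound 2 (within the scatter), which stayed within the scatter. For compound 4 an efficacy of 84% is expected, roughly between 72% and 96%.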

Compound 4, largest response reached (reported as efficacy), in percent of the reference or control that the assay uses: 74%
Compound 4: middle estimate off by 10 percentage points, on the high side; low and high end bracket the measured number.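

Set side by side, the two fluoro steps in this assay cannot be told apart: the same change on two cores in this assay, a number 7 percentage points higher (within the scatter) from compound 1 to compound 2 and a number 7 percentage points lower (within the scatter) from compound 3 to compound 4, 14 percentage points apart, within the scatter of two such steps

The new step reads a number 7 percentage points lower from compound 3 to compound 4 (within the scatter), with a number 10 percentage points lower from compound 2 to compound 4 (within the scatter) and a number 3 percentage points lower from compound 1 to compound 4 (within the scatter) beside it, so every step among these compounds stays within the scatter. This shows no effect of the fluoro change on maximal response that can be read on either core, and it does not show that the change acts alike on both, since steps this small cannot separate the two cores.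

Open, as far as these compounds go, is how a hydroxy group or an amine would read in place of the fluoro on that saturated chain carbon. Also open, from the compounds shown here alone, is whether a trifluoromethyl group would give a step beyond the scatter.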